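The source may report more compounds than this note shows. Statements on the series, on what has been measured and on what is new or still open speak of the compounds shown alone.

Measured compounds:
compound 1, `CCOC(=O)C1CCN(C(=O)CN2CN(c3ccccc3)C3(CCN(C(=O)c4ccc(C5CCCCC5)cc4)CC3)C2=O)CC1` — 900 nM
compound 2, `CS(=O)(=O)NCCCNC(=O)CN1CN(c2ccccc2)C2(CCN(C(=O)c3ccc(C4CCCCC4)cc3)CC2)C1=O` — 3800 nM

In an assay on HEK293 cells for displacement of a labelled ligand from NPC1-like intracellular cholesterol transporter 1 (Homo sapiens) (on this read-out higher numbers stand for weaker inhibition and lower numbers for stronger inhibition), compound 1 gives 900 nM, and compound 2 gives 3800 nM. Going by the values given here, the one measured step between them, a 4.2-fold higher number from compound 1 to compound 2 (0.63 log units; beyond the scatter), is the only comparison available, and it leaves compound 2 with the higher of the two numbers, so the weaker binding of the pair.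

Compound 3, `NCCNC(=O)CN1CN(c2ccccc2)C2(CCN(C(=O)c3ccc(C4CCCCC4)cc3)CC2)C1=O`, has not been measured in this assay. It differs from compound 2 by amino in place of (methanesulfonamido)methyl on a saturated chain carbon, two bonds along the chain from an amide-type nitrogen; the chain that carries the terminal amide substituent is thus shortened and its sulfonamide is lost. The step from compound 1 to compound 2 concerns the same terminal amide substituent but a different exchange, so it bears on this step only loosely, and it gives no direction for the present change. With nothing in the shown pair that points one way, the expected step of a 1.1-fold lower number from compound 2 to compound 3 (0.04 log units; within the scatter) is put close to no change, with wide uncertainty on both sides. Compound 3 is therefore expected to give about 3500 nM in this assay, in the range 900 nM to 14000 nM.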

Compound 3, half-maximal inhibitory concentration: 3800 nM
Compound 3: middle estimate off by 1.1-fold (0.04 log units), on the low side; the measured number falls inside the stated range.
By their numbers in this assay, from the lowest: compound 1; then compounds 2 and 3 (each within the scatter of the next).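

In this assay, amino in place of (methanesulfonamido)methyl on a saturated chain carbon, two bonds along the chain from an amide-type nitrogen, gives no change at the digits printed from compound 2 to compound 3 (within the scatter), so here the read-out does not separate the 3-(methanesulfonamido)propyl chain from the 2-aminoethyl chain. With (2-aminoethyl)amino in place of 4-(ethoxycarbonyl)piperidin-1-yl on a carbonyl carbon, the result is a 4.2-fold higher number from compound 1 to compound 3 (0.63 log units; beyond the scatter), which matches the step already seen for the sulfonamide chain and leaves compound 1 with the lowest number of the three. No supporting evidence bears on why these chains match or why both differ from the piperidine substituent.

The compounds shown leave open whether the lower number of compound 1 belongs to its piperidine ring or to its ethyl ester, a question that a piperidine carrying a carboxylic acid or no substituent at all would address. They also leave open whether the match between the two chains would hold for a 4-aminobutyl chain, or for a 2-aminoethyl chain whose terminal amine carries an acetyl group.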